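The source may report more compounds than this note shows. Statements on the series, on what has been measured and on what is new or still open speak of the compounds shown alone.

Measured compounds in an assay on isolated protein for antagonist activity at Bile acid receptor (Homo sapiens), read by HTRF, with a stated time of 30 min; a lower number here means a stronger inhibitor, a higher number a weaker inhibitor:
Compound 1 `CC(C)(C)c1cc(OC(=O)/C=C/c2ccccc2)ccc1O` reaches only a limit, > 100000 nM.
Compound 2 `CC(C)(C)c1cc(OC(=O)c2ccc([N+](=O)[O-])cc2Cl)ccc1O` gives 8800 nM.
Compound 3 `CC(C)(C)c1cc(OC(=O)c2c(Cl)cc([N+](=O)[O-])cc2Cl)ccc1O` gives 5900 nM.

Compound 3 holds the lowest of the two numbers in this assay. Its nearest neighbour is compound 2, and the step of a 1.5-fold lower number from compound 2 to compound 3 (0.17 log units; within the scatter) lies within the scatter, so the two compounds cannot be set in order. Compound 1 sits at the limit of > 100000 nM in this assay, at which 1 of the 3 values shown sits, so it contributes no number to compare.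

Compound 4 `CC(C)(C)c1cc(OC(=O)c2c(Cl)cc(N)cc2Cl)ccc1O` differs from compound 3 by amino in place of nitro on an aromatic carbon. For the measured compounds named here, none of the measured steps touches this kind of exchange. Going by the values given here, the only step that is measured, a 1.5-fold lower number from compound 2 to compound 3 (0.17 log units; within the scatter), concerns chloro in place of hydrogen and stayed within the scatter, while compound 1 differs from the other two across the whole ester part, so it offers nothing on a change at the aromatic ring of the acid. The direction of the step to compound 4 therefore cannot be read from the measured pairs, and a wide range must be allowed around a middle near compound 3.

Compound 4 is expected to give about 15000 nM in this assay, with a range from 3000 nM to 100000 nM. This corresponds to an expected step of a 2.5-fold higher number from compound 3 to compound 4 (0.41 log units; beyond the scatter).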

Compound 4, half-maximal inhibitory concentration: 600 nM
For compound 4 the middle estimate is 25-fold (1.40 log units) above the measured one, outside the stated range (below it).
By their numbers in this assay, from the lowest: compound 4; then compounds 3 and 2 (each within the scatter of the next). At a limit, above all of these: compound 1.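

In this assay, amino in place of nitro, on the aromatic carbon that is para to a large group and meta to two chloro groups, gives a step beyond the scatter: a 9.8-fold lower number from compound 3 to compound 4 (0.99 log units; beyond the scatter). For the compounds shown here, this is the first change between two compounds differing in one place to separate them clearly, since the only earlier such step, a 1.5-fold lower number from compound 2 to compound 3 (0.17 log units; within the scatter), stayed within the scatter, and it shows that the number responds to the group at this position. Amino also brings a hydrogen-bond donor that nitro lacks, but nothing measured here tells whether that donor or any other difference between the two groups accounts for the stronger inhibition.

From the compounds shown here alone, it remains open whether a hydroxyl, a methylamino or an acetamido group at this place would follow amino, and so whether the gain needs a free amine or simply the absence of nitro. Also open, going by these compounds, is whether chloro in place of hydrogen, which made no clear difference with nitro present, would matter with amino present.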